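Amide series on two cores, all at the assay limit

This account rests on a few compounds, and the source may have more. Where it says the series, first, only, none or still open, it means among the compounds named here.

Compound 1 `C/C(=C\c1cc(-c2ccc(C)nc2)co1)C(N)=O` and compound 2 `C/C(=C\c1cc(-c2ccc(F)nc2)co1)C(N)=O` share one core; compound 3 `C/C(=C\c1cc(-c2ccc(C)cc2)cs1)C(N)=O` and compound 4 `C/C(=C\c1cc(-c2ccc(F)cc2)cs1)C(N)=O` share another, and the difference between the two cores is not broken down here. In a functional assay on BGC-823 cells (Homo sapiens) for cytotoxicity, read by CCK-8 assay, with a stated time of 24 h (a lower number here means a stronger inhibitor, a higher number a weaker inhibitor), compound 1 reaches only a limit, > 50000 nM. In this assay compound 2 likewise gives only a limit, > 50000 nM. The change from compound 1 to compound 2 is fluoro in place of methyl on an aromatic carbon and its step, a step that the two limits leave unreadable from compound 1 to compound 2, cannot be sized because of the limit of > 50000 nM in this assay, at which 3 of the 3 values shown sit. In this assay compound 3 also sits at a limit, > 50000 nM, and that limit is all an expectation for compound 4 can rest on. Compound 4 carries the same kind of change, (fluoro in place of methyl on an aromatic carbon); here the ring is of carbon only, whereas in compound 2 the ring holds 1 nitrogen and the fluoro sits next to the ring nitrogen. The expected step is flat, a step that the limit leaves unreadable from compound 3 to compound 4, because of the limit of > 50000 nM in this assay, at which 3 of the 3 values shown sit. Compound 4 is expected to give 80000 nM, between 30000 nM and 300000 nM, most probably reported only as a limit.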

Compound 4, half-maximal inhibitory concentration: > 50000 nM
Compound 4: only a limit was reported; the forecaster's own chance of this, stated with the estimate: 85%; the middle value is on the limit's open side.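

In this assay no new step can be read between compound 3 and compound 4 because both results are limits and not numbers: the limit of > 50000 nM in this assay, at which 4 of the 4 values shown sit. The compounds shown leave open how far any of them lies from that limit, and whether fluoro in place of methyl or the difference between the two cores changes cytotoxicity at all.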